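The source may hold more compounds than are shown below. What is called first, only, known or untested is meant among the compounds shown, and "the series" means these compounds.

Compound 1 `CCCCCCCCC(CCO)n1cnc2c(N(C)C)ncnc21`, compound 2 `CCCCCCCCC(CCO)n1cnc2c(N)ncnc21`, compound 3 `CCCCCCCCCCC(CCO)n1cnc2c(N(C)C)ncnc21` and compound 4 `CCCCCCCCCCC(CCO)n1cnc2c(N)ncnc21` make up a small set built on a shared core carrying a long saturated chain. In a functional assay on SW480 cells (Homo sapiens) for antiproliferative activity, read by MTT assay, with a stated time of 48 h (a lower number here means a stronger inhibitor, a higher number a weaker inhibitor), compound 1 gives 21600 nM, and compound 2 gives 20700 nM. Compound 2 differs from compound 1 by amino in place of dimethylamino on an aromatic carbon, and that change made a step of a 1.0-fold lower number from compound 1 to compound 2 (0.02 log units; within the scatter). Compound 3 gives 3320 nM in this assay, the lowest number among the three measured compounds. Its core differs from that of compound 1 by ethyl in place of hydrogen on a saturated chain carbon, nine bonds along the chain from an aromatic nitrogen, a change that made a step of a 6.5-fold lower number from compound 1 to compound 3 (0.81 log units; beyond the scatter). Within the data shown here, no step between compound 2 and compound 3 is broken down here; their two values simply show the lower number for compound 3.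

Compound 4 has not yet been measured. It differs from compound 3 by amino in place of dimethylamino on an aromatic carbon, the same change that turns compound 1 into compound 2, at a place described in identical words. Since that earlier change moved the number only within the scatter, compound 4 is expected to land close to compound 3. For compound 4 the expected step is a 1.0-fold higher number from compound 3 to compound 4 (0.01 log units; within the scatter). This rests on the step of a 1.0-fold lower number from compound 1 to compound 2 (0.02 log units; within the scatter) made by the same change. Compound 4 is therefore estimated at 3400 nM in this assay, with a range from 1700 nM to 7000 nM.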

Compound 4, half-maximal inhibitory concentration: 1200 nM
Compound 4: the middle estimate sits 2.8-fold (0.45 log units) above what was measured; the measured number lies below the stated range.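

In this assay, amino in place of dimethylamino made a step of a 2.8-fold lower number from compound 3 to compound 4 (0.44 log units; beyond the scatter), and set beside the same change on the other core, this step does not differ from it beyond the scatter: the same change on two cores in this assay, a 1.0-fold lower number (0.02 log units; within the scatter) from compound 1 to compound 2 and a 2.8-fold lower number (0.44 log units; beyond the scatter) from compound 3 to compound 4, 2.7-fold (0.42 log units) apart, within the scatter of two such steps. Ethyl in place of hydrogen on a saturated chain carbon, nine bonds along the chain from an aromatic nitrogen, made a step of a 17-fold lower number from compound 2 to compound 4 (1.24 log units; beyond the scatter), and this change also lowered the number on both cores by amounts that cannot be told apart: the same change on two cores in this assay, a 6.5-fold lower number (0.81 log units; beyond the scatter) from compound 1 to compound 3 and a 17-fold lower number (1.24 log units; beyond the scatter) from compound 2 to compound 4, 2.7-fold (0.42 log units) apart, within the scatter of two such steps. Among these compounds, each change therefore carries from one core to the other within the scatter in these four compounds, but with only one pair of steps for each change, this neither shows that the amino step depends on the core nor rules it out, and it sets no rule for the wider series.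

The compounds shown leave open whether a methylamino group or a cyclic amine on that aromatic carbon would fit the same picture. They also leave open whether a shorter chain or a longer chain would extend the steps seen with the ethyl change, or whether a carboxylic acid in place of the chain's hydroxyl would leave them intact.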